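Swapping the aryl group on the amine of compound 2

A few compounds are considered here, and "the series" means these few. Any claim that something is new, unique, unknown or untested is made for them only; others in the source may bear on it.

Of the compounds shown here, three built around one shared core have been measured in a functional assay on NCI-H520 cells (Homo sapiens) for inhibition, read by MTT assay, with a stated time of 48 h, tested at 10 uM; a higher number here means more inhibition at the concentration tested (going by the name of the read-out), a lower number less inhibition. Compound 1, with structure `COc1ccc(OC)c(Nc2cc(NC(=O)Nc3c(Cl)cccc3Cl)ncn2)c1`, gives 74% in this assay. Compound 2, with structure `COc1cc(NC(=O)Nc2cc(Nc3ccc(C)c(F)c3)ncn2)cc(OC)c1`, gives 30.6%, and compound 3, with structure `COc1cc(Nc2cc(NC(=O)Nc3c(Cl)cccc3Cl)ncn2)cc(C(F)(F)F)c1`, gives 23.1%. On these numbers compound 2 stands second of three: its value and that of compound 3 lie within the usual scatter of each other, so no order between them can be read, while compound 1 stands clearly higher than compound 2, beyond the scatter.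

Compound 4, with structure `CCc1ccc(Nc2cc(NC(=O)Nc3cc(OC)cc(OC)c3)ncn2)cc1`, has not yet been measured in this assay. It differs from compound 2 in one place: 4-ethylphenyl in place of 3-fluoro-4-methylphenyl on a nitrogen on an aromatic ring. Within the data shown here, no pair of measured compounds that differ in a single place is available, so nothing shows how far such a swap of one aryl group for another can move the read-out. Among the measured compounds shown here, the three measured compounds differ from one another in several places at once, and their spread says only that changes of this kind may or may not matter.

For the measured compounds named here, with no guiding step, the change from compound 2 to compound 4 is expected to produce a step of a number 0.6 percentage points lower from compound 2 to compound 4 (within the scatter), that is, none beyond the scatter. Compound 4 is therefore estimated to give 30% in this assay, within a range from 10% to 55%.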

Compound 4, a percentage reported as inhibition, at one concentration (the size of the read-out at that concentration, not a potency): 23.5%
The estimate for compound 4 lay 6.5 percentage points above the measured number; low and high end bracket the measured number.
By their numbers in this assay, from the lowest: compounds 3, 4 and 2 (each within the scatter of the next); then compound 1.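

Among these compounds, this pair is the first to differ in a single place, so it gives the first direct reading of what an aryl swap on this nitrogen can do in this assay. Putting 4-ethylphenyl in place of 3-fluoro-4-methylphenyl gives a step of a number 7.1 percentage points lower from compound 2 to compound 4 (within the scatter), so this exchange, which removes the fluorine and keeps the same count of heavy atoms, does not separate the two compounds in this assay. Nothing measured here offers an explanation for how the two compounds compare.

Going by these compounds, both of these aryl groups are carbon rings bearing only alkyl or fluorine substituents, so it remains open whether an amine or a carboxylic acid on the ring, or a longer chain in place of the ethyl, would move the number beyond the scatter. On these data alone, it is also open whether the same swap would read alike with the different groups found elsewhere on compound 1, since a single step on one pair cannot show how the change behaves on another.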